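The source may report more compounds than this note shows. Statements on the series, on what has been measured and on what is new or still open speak of the compounds shown alone.

Working notes on the ester tail.

Within the data shown here, compound 2 `CCOc1cc(NC(=O)C2(NC(=O)c3ccc4c(C5CCCC5)c(-c5ncc(Cl)cn5)n(C)c4c3)CCC2)ccc1/C=C/C(=O)OCCOCCOC` gives 0.85 h in an ADME assay (liver) for pharmacokinetics, with Liver microsome (Homo sapiens) as the target, using microsomes (a higher number here means that the compound lasts longer, a lower number that the compound disappears faster), the only plain number in the set. Compound 1 `CCCOC(=O)/C=C/c1ccc(NC(=O)C2(NC(=O)c3ccc4c(C5CCCC5)c(-c5ncc(Cl)cn5)n(C)c4c3)CCC2)cc1OCC` sits at the limit of > 5 h in this assay, at which 1 of the 2 values shown sits, with > 5 h, a limit rather than a number. Among the measured compounds shown here, the single measured step, an at least 5.8-fold lower number from compound 1 to compound 2 (0.76 log units; beyond the scatter), shows that the ester tail alone moves the half-life strongly. Compound 3 `CCCN(C)C(=O)COC(=O)/C=C/c1ccc(NC(=O)C2(NC(=O)c3ccc4c(C5CCCC5)c(-c5ncc(Cl)cn5)n(C)c4c3)CCC2)cc1OCC` alters that tail again: methyl(propyl)carbamoyl in place of (2-methoxyethoxy)methyl on a saturated chain carbon bound to an oxygen next to a carbonyl group. For the measured compounds named here, no measured step covers this particular exchange, so direction is uncertain, though a return toward longer values is plausible. Compound 3 is expected to give 1.8 h (range 0.5 h to 6 h), an estimated step of a 2.1-fold higher number from compound 2 to compound 3 (0.33 log units; beyond the scatter).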

Compound 3, half-life: 0.317 h
The estimate for compound 3 lay 5.7-fold (0.75 log units) above the measured number; measured number below the stated range.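

In this assay, methyl(propyl)carbamoyl in place of (2-methoxyethoxy)methyl on this saturated chain carbon gives a 2.7-fold lower number from compound 2 to compound 3 (0.43 log units; beyond the scatter). Both tails that replace the ethyl of compound 1 therefore shorten the half-life, and methyl(propyl)carbamoyl in place of ethyl gives an at least 15-fold lower number from compound 1 to compound 3 (1.19 log units; beyond the scatter). That step starts from a limit rather than a number: the limit of > 5 h in this assay, at which 1 of the 3 values shown sits.

The compounds shown do not separate the carbonyl of methyl(propyl)carbamoyl from its methyl and propyl groups. On these data alone, how a carboxylic acid, an amine or a longer chain on this carbon would fare remains open.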